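Methoxyphenyl position in a weakly active acid series

The source may report more compounds than this note shows. Statements on the series, on what has been measured and on what is new or still open speak of the compounds shown alone.

The three measured compounds are compared in an assay on cells for antagonist activity at vitamin D3 receptor (Homo sapiens), read by a luciferase reporter; a lower number here means a stronger inhibitor, a higher number a weaker inhibitor. Compound 1 `COc1ccccc1-c1nc(C)c(COc2ccccc2C(=O)O)o1` returns in this assay only a limit, > 80000 nM. Compound 2 `COc1cccc(-c2nc(C)c(COc3ccccc3C(=O)O)o2)c1` returns in this assay only a limit as well, > 33000 nM. Compound 3 `COc1ccccc1-c1nc(C)c(COc2ccc(C(=O)O)cc2)o1` returns in this assay also only a limit, > 80000 nM. The difference between the cores of compound 1 and compound 3 is not broken down here.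

The change from compound 1 to compound 2 is 3-methoxyphenyl in place of 2-methoxyphenyl on an aromatic carbon. The step that the two limits leave unreadable from compound 1 to compound 2 cannot be read because both of its ends sit at limits, namely the limit of > 80000 nM in this assay, at which 2 of the 3 values shown sit, and (the limit of > 33000 nM in this assay, at which 1 of the 3 values shown sits), so nothing is known about the size or direction of this change within the series.

Compound 4 `COc1cccc(-c2nc(C)c(COc3ccc(C(=O)O)cc3)o2)c1` has not yet been measured in this assay. Among the compounds with values here, it differs from compound 3 by 3-methoxyphenyl in place of 2-methoxyphenyl on an aromatic carbon, which is the same change as the one made from compound 1 to compound 2, at the same place on the shared core.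

For compound 4 the step that the limit leaves unreadable from compound 3 to compound 4 is expected to be unreadable in the same way, because compound 3 itself sits at the limit of > 80000 nM in this assay, at which 2 of the 3 values shown sit, and the earlier instance of the change gave a step that the two limits leave unreadable from compound 1 to compound 2. Compound 4 is therefore expected in this assay at about 100000 nM, within a range from 30000 nM to 300000 nM, and most likely to be reported once more as a limit rather than as a number.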

Compound 4, half-maximal inhibitory concentration: > 80000 nM
Compound 4 ended at the assay's limit (the forecaster's own chance of this, stated with the estimate: 85%); the middle value does not contradict the limit.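

In this assay compound 4 gives > 80000 nM, which is a limit and not a number. Within the data shown here, with compound 3 also at a limit, the change from compound 3 to compound 4 cannot be read, and no new step follows. The compounds shown leave open whether 3-methoxyphenyl in place of 2-methoxyphenyl alters inhibition at all, in either direction, on either core.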